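The source may hold more compounds than are shown below. What is called first, only, known or untested is meant among the compounds shown, and "the series" means these compounds.

Compound 1 (`COc1ccc(/C=C(\C(=O)c2ccc(Br)cc2)S(=O)(=O)c2ccc(Br)cc2)c(F)c1`) gives 10000 nM
Compound 2 (`O=C(/C(=C\c1ccc(F)cc1F)S(=O)(=O)c1ccc(Br)cc1)c1ccc(Br)cc1`) gives 7500 nM

In a functional assay on DU-145 cells (Homo sapiens) for inhibition, read by trypan blue exclusion, with a stated time of 96 h (on this read-out higher numbers stand for weaker inhibition of growth and lower numbers for stronger inhibition of growth), compound 2 stands at 7500 nM and compound 1 at 10000 nM on the same scale. These two values lie within the scatter of each other, so they cannot be ranked.

Compound 3 (`Nc1c(Br)cc(Br)cc1/C=C(\C(=O)c1ccc(Br)cc1)S(=O)(=O)c1ccc(Br)cc1`) differs from compound 2 in one place: 2-amino-3,5-dibromophenyl in place of 2,4-difluorophenyl on a double-bonded chain carbon bound to a double-bonded chain carbon.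

Going by the values given here, only one measured step bears on this change, fluoro in place of methoxy on an aromatic carbon (a 1.3-fold lower number from compound 1 to compound 2 (0.12 log units; within the scatter)). That step is small and stays within the scatter. It swaps a single group on the ring, while here the whole aromatic group is replaced, and neither measured compound carries an amino group on that ring. It therefore offers weak guidance and points in no direction, so no shift beyond the scatter is expected in this assay, and the estimated step is small (a 1.1-fold lower number from compound 2 to compound 3 (0.03 log units; within the scatter)).

For compound 3 the estimated value is 7000 nM (expected range 2000 nM to 20000 nM).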

Compound 3, concentration for 50% growth inhibition: 25000 nM
For compound 3 the middle estimate is 3.6-fold (0.55 log units) below the measured one; measured number outside the range, above it.
By their numbers in this assay, from the lowest: compounds 2 and 1 (each within the scatter of the next); then compound 3.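

Swapping the aromatic group on a double-bonded chain carbon bound to a double-bonded chain carbon does change the result in this assay: 2-amino-3,5-dibromophenyl in place of 2,4-difluorophenyl gives a 3.3-fold higher number from compound 2 to compound 3 (0.52 log units; beyond the scatter) and in place of 2-fluoro-4-methoxyphenyl gives a 2.5-fold higher number from compound 1 to compound 3 (0.40 log units; beyond the scatter) on the same scale. These are the first steps shown that pass beyond the scatter, and both point towards weaker inhibition of growth, so this position is not indifferent to what sits there, even though the fluoro and methoxy exchange between the two earlier compounds left no readable difference. Nothing available here accounts for the loss of activity.

The entering group brings an amino group and bromines at once and the fluorines leave at the same time, so these compounds cannot say which of those parts carries the step. Going by these compounds, how the result would read with only an amino group on the phenyl ring, only the bromines, or a different group such as a hydroxyl or a nitrile also stays open.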